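The source may hold more compounds than are shown below. What is called first, only, known or untested is meant among the compounds shown, and "the series" means these compounds.

Measured so far:
- Compound 2 `CC1CCC(=NNc2ccccc2)c2ncc(C(=O)O)c(=O)n21` gives 0.6 umol/kg
- Compound 3 `CC1CC/C(=N\Nc2ccc(Br)cc2)c2ncc(C(=O)O)c(=O)n21` gives 0.8 umol/kg
- Compound 1 `CCOC(=O)c1cnc2n(c1=O)C(C)CC/C2=N\Nc1ccccc1C(=O)O` gives 10 umol/kg

These three compounds were tested in a functional assay on the whole organism for inhibition, with Rattus norvegicus as the target; on this read-out lower numbers stand for an effect already at smaller amounts and higher numbers for an effect only at larger amounts of compound. Compound 3 stands second highest of the three numbers. Its nearest neighbour is compound 2, whose number is within the scatter of repeated measurements, so the two cannot be told apart on this read-out. Within the data shown here, the furthest is compound 1, whose number lies well beyond the scatter; compound 1 differs from compound 3 in more than one place, so no single step can be drawn between them.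

The next compound, compound 4 `CNC(=O)c1ccc(N/N=C2\CCC(C)n3c2ncc(C(=O)O)c3=O)cc1`, is not yet measured. It differs from compound 3 by one change: methylcarbamoyl in place of bromo on an aromatic carbon. Compound 2 and compound 3 show that a bare ring and a bromo at this position give numbers within the scatter of each other, so the position tolerates at least that much. Among the measured compounds shown here, a larger group with a hydrogen-bond donor and acceptor is new here, and no measured pair shows its effect.

The step of a 1.5-fold higher number from compound 3 to compound 4 (0.18 log units; within the scatter) is expected to be small, leaning towards a higher number, and may fall within the scatter. Compound 4 is therefore estimated at 1.2 umol/kg in this assay, with a range from 0.35 umol/kg to 4 umol/kg.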

Compound 4, dose for 50% inhibition: 9.6 umol/kg
Estimate against measurement, compound 4: 8.0-fold (0.90 log units) below; the measured number lies above the stated range.
By their numbers in this assay, from the lowest: compounds 2 and 3 (each within the scatter of the next); then compounds 4 and 1 (each within the scatter of the next).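

In this assay the change from bromo to methylcarbamoyl on the aromatic carbon gives a 12-fold higher number from compound 3 to compound 4 (1.08 log units; beyond the scatter) and so moves the number well beyond the scatter. Compound 2, with a bare ring, and compound 3, with bromo, could not be told apart, so the position seemed to accept different substituents, but this result shows that the acceptance does not extend to every group. No measurement shown here explains why methylcarbamoyl raises the number so far.

The compounds shown cannot separate the contribution of the amide hydrogen from that of the carbonyl or the methyl group. They also leave open how a methyl ester, a primary amide, an amine or a carboxylic acid would behave on this aromatic carbon.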